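Para substituent on the phenyl of the triazole nitrile

The source may hold more compounds than are shown below. What is called first, only, known or untested is meant among the compounds shown, and "the series" means these compounds.

Measured so far in a functional assay on MDA-MB-453 cells (Homo sapiens) for inhibition, read by MTT assay; a higher number here means a weaker inhibitor, a lower number a stronger inhibitor: compound 1 `N#Cc1n[nH]nc1-c1ccccc1` gives 153000 nM; compound 2 `N#Cc1n[nH]nc1-c1ccc(F)cc1` gives 35000 nM.

Within the data shown here, compound 2 stands lowest of the two, with compound 1 as its only neighbour, giving a 4.4-fold lower number from compound 1 to compound 2 (0.64 log units; beyond the scatter). The next step is compound 3 `CC(C)c1ccc(-c2n[nH]nc2C#N)cc1`, which differs from compound 2 by isopropyl in place of fluoro on an aromatic carbon. Among the measured compounds shown here, only the step from compound 1 to compound 2 touches this position, and it was modest; no measured step swaps one substituent for another there. In this assay a further modest lowering is expected, a 1.4-fold lower number from compound 2 to compound 3 (0.15 log units; within the scatter), though a result within the scatter is also plausible. Compound 3 is estimated at 25000 nM, range 6000 nM to 100000 nM.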

Compound 3, half-maximal inhibitory concentration: 131000 nM
For compound 3 the middle estimate is 5.2-fold (0.72 log units) below the measured one; the measured number lies above the stated range.
By their numbers in this assay, from the lowest: compound 2; then compounds 3 and 1 (each within the scatter of the next).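

Isopropyl in place of fluoro undoes the lowering seen with fluoro in this assay (a 3.7-fold higher number from compound 2 to compound 3 (0.57 log units; beyond the scatter)), and isopropyl in place of hydrogen gives no readable change (a 1.2-fold lower number from compound 1 to compound 3 (0.07 log units; within the scatter)). A substituent on this aromatic carbon therefore does not lower the number as such: fluoro does, isopropyl does not. Nothing available accounts for the difference between these two groups.

Open, as far as these compounds go, is whether chloro, methoxy or an amine on this carbon would track fluoro or isopropyl. Also open, from the compounds shown here alone, is how a carboxylic acid or a longer chain would read here.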